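The source may report more compounds than this note shows. Statements on the series, on what has been measured and on what is new or still open speak of the compounds shown alone.

In a functional assay on RAW264.7 cells (Mus musculus) for inhibition, read by ELISA, with a stated time of 24 h (a higher number here means that more compound is needed for the effect, a lower number that less compound is needed), compound 1 `CC/C=C\C[C@H]1C(=O)C=C[C@H]1CC(=O)OC(C)CC` gives 22000 nM and compound 2 `CC/C=C\C[C@H]1C(=O)C=C[C@H]1CC(=O)OC(C)COC` gives 23000 nM, so compound 2 stands level with compound 1. Compound 3 `CC/C=C\C[C@H]1C(=O)C=C[C@H]1CC(=O)OC(C)c1ccccc1` carries phenyl in place of methoxymethyl on a saturated chain carbon bound to an oxygen next to a carbonyl group and a saturated chain carbon. Within the data shown here, the only measured step, methoxy in place of methyl, is a 1.0-fold higher number from compound 1 to compound 2 (0.02 log units; within the scatter). With so little evidence, and a larger change here, no step beyond the scatter is expected in this assay. The estimated step is a 1.3-fold lower number from compound 2 to compound 3 (0.11 log units; within the scatter). For compound 3 the expected value is 18000 nM, with an estimated range of 7000 nM to 40000 nM.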

Compound 3, half-maximal effective concentration: 18000 nM
Beside the measured number, compound 3's estimate shows no gap at the digits printed, within the range that was stated.
By their numbers in this assay, from the lowest: compounds 3, 1 and 2 (each within the scatter of the next).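

In this assay phenyl in place of methoxymethyl gives a 1.3-fold lower number from compound 2 to compound 3 (0.11 log units; within the scatter) and phenyl in place of ethyl gives a 1.2-fold lower number from compound 1 to compound 3 (0.09 log units; within the scatter) so a six-membered aromatic ring on this saturated chain carbon stands level with both open chains. The earlier compounds shown here carried only open chains here and could not show this. From the compounds shown here alone, whether an amine, a carboxylic acid or a longer chain on this carbon would give a step beyond the scatter remains open. Nothing on hand offers a reason for these numbers.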